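The compounds below may be only part of what the source reports. "The series", "measured", "known", "first", "only" and "open" are said of these compounds alone.

In a functional assay on J774.A1 cells (Mus musculus) for inhibition, read by Griess assay, with stated times of 1 h and 24 h (a lower number here means a stronger inhibitor, a higher number a weaker inhibitor), compound 2 (`CC(C)COc1ccccc1C1CC(=O)c2ccccc2O1`) gives 33200 nM and stands level with its two measured relatives. Compound 3 (`CC(C)=CCOc1ccccc1C1CC(=O)c2ccccc2O1`) gives 34300 nM in this assay and compound 1 (`CC(C)CCOc1ccccc1C1CC(=O)c2ccccc2O1`) gives 42600 nM there, so all three values lie within the scatter of one another. The step followed here leads to compound 4 (`COc1ccccc1C1CC(=O)c2ccccc2O1`), which has not yet been measured. In it, hydrogen takes the place of isopropyl on a saturated chain carbon bound to an oxygen on an aromatic ring (hydrogen in place of isopropyl on a saturated chain carbon bound to an oxygen on an aromatic ring) and the isobutoxy of compound 2 thus becomes methoxy. Measured steps at this same place bear on the change, and they are small: (a 1.3-fold lower number from compound 1 to compound 2 (0.11 log units; within the scatter)) and (a 1.2-fold lower number from compound 1 to compound 3 (0.09 log units; within the scatter)) both stay within the scatter. Within the data shown here, none of the measured compounds carries a group as small as methoxy here, so the data give no direction and the range must stay wide. Going by the step to compound 3 (a 1.0-fold higher number from compound 2 to compound 3 (0.01 log units; within the scatter)) and the other two, no step beyond the scatter is expected in this assay in either direction. The estimated size is a 1.1-fold higher number from compound 2 to compound 4 (0.04 log units; within the scatter) and no more than that is expected. For compound 4 the expected value is 36000 nM with an estimated range from 16000 nM to 80000 nM as its span.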

Compound 4, half-maximal inhibitory concentration: 44500 nM
Beside the measured number, compound 4's estimate is 1.2-fold (0.09 log units) below it; low and high end bracket the measured number.
By their numbers in this assay, from the lowest: compounds 2, 3, 1 and 4 (each within the scatter of the next).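

Shortening the group on the oxygen to methoxy in compound 4 leaves the number in this assay essentially in place: the comparisons give a 1.3-fold higher number from compound 2 to compound 4 (0.13 log units; within the scatter), a 1.3-fold higher number from compound 3 to compound 4 (0.11 log units; within the scatter) and a 1.0-fold higher number from compound 1 to compound 4 (0.02 log units; within the scatter). The earlier compounds shown here only exchanged isobutyl, isopropyl and 2-methylprop-1-en-1-yl with one another on the saturated chain carbon bound to an oxygen on an aromatic ring, whereas hydrogen now stands there and the isopropyl is gone entirely, so the flat picture holds across all four compounds with none going against it. Nothing among the available data explains why this position tolerates the change so evenly.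

What the compounds leave open is whether any group at this place can move the number beyond the scatter, for example an amine or a carboxylic acid at the end of the chain, a much longer chain, or a free hydroxyl in place of the methoxy. They also leave open whether a change elsewhere on the shared core would matter more than this one, since all four compounds differ only at this one place.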